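Swapping the Furan Attachment Point on a Dihydropyrimidinone Core

The source may hold more compounds than are shown below. What is called first, only, known or untested is meant among the compounds shown, and "the series" means these compounds.

Two compounds have numbers so far:
compound 1 `CCN(CC)C(=O)C1=C(C)NC(=O)NC1c1ccoc1` gives 37%
compound 2 `CCSC(=O)C1=C(C)NC(=O)NC1c1ccco1` gives 14%

Both were tested in an assay on membranes from HeLa cells for displacement of a labelled ligand from adenosine receptor A3 (Homo sapiens), read by scintillation counting, with a stated time of 180 min, tested at 1 uM; on this read-out lower numbers stand for less inhibition and higher numbers for more inhibition at the one concentration tested (going by the name of the read-out). Compound 2 stands lowest of the two numbers; its nearest neighbour is compound 1, whose value lies higher by a gap beyond the usual scatter. Going by the values given here, no single-change step between measured compounds exists here, since compound 1 and compound 2 differ in two places at once, so what that gap means for either change alone is not known.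

Compound 3 `CCSC(=O)C1=C(C)NC(=O)NC1c1ccoc1` is not yet measured. It differs from compound 2 in one place: furan-3-yl in place of furan-2-yl on a saturated ring carbon. Compound 3 thus carries the furan-3-yl of compound 1 together with the (ethylsulfanyl)carbonyl group of compound 2.

The expected size of this step is modest: a rise in this assay from compound 2 is thought plausible because compound 1, which also bears furan-3-yl, gives 37%, though part of that gap may belong to the other difference. The estimated step is a number 11 percentage points higher from compound 2 to compound 3 (beyond the scatter). Compound 3 is expected to give 25%, with a range from 8% to 45%.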

Compound 3, a percentage reported as inhibition, at one concentration (the size of the read-out at that concentration, not a potency): 1%
Compound 3: middle estimate off by 24 percentage points, on the high side, and the stated range ends above it.
By their numbers in this assay, from the lowest: compound 3; then compound 2; then compound 1.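

Compound 3 and compound 2 hold the same atoms, and in this assay moving the furan attachment on the saturated ring carbon gives a number 13 percentage points lower from compound 2 to compound 3 (beyond the scatter), so with the (ethylsulfanyl)carbonyl group in place, the point of attachment alone changes the read-out and furan-2-yl sits above furan-3-yl. Going by these compounds alone, with furan-3-yl held fixed, ethylsulfanyl in place of diethylamino on a carbonyl carbon gives a number 36 percentage points lower from compound 1 to compound 3 (beyond the scatter), which shows that the group on the carbonyl also counts on this core, a point the two-place difference between the earlier compounds could not settle. Nothing measured here explains either step.

Whether furan-2-yl would also sit above furan-3-yl alongside diethylamino stays open, since the compounds shown pair diethylamino only with furan-3-yl, and so the two changes cannot yet be tested for independence. On these data alone, it is equally open how an ethoxy group or a dimethylamino group on the carbonyl, or a thiophen-2-yl or phenyl ring on the saturated ring carbon, would read in this assay.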